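This account rests on a few compounds, and the source may have more. Where it says the series, first, only, none or still open, it means among the compounds named here.

Measured compounds:
- compound 1 `CCCCCC#Cc1cn(CCC(COC(C)=O)COC(C)=O)c(=O)n(C(=O)c2ccccc2)c1=O` with 62200 nM in a functional assay on MCF7 cells (Homo sapiens) for antiproliferative activity, read by MTT assay, with a stated time of 72 h; on this read-out lower numbers stand for stronger inhibition and higher numbers for weaker inhibition
- compound 2 `O=c1[nH]c(=O)n(CCC(CO)CO)cc1C#Cc1cc(F)cc(F)c1` with 63100 nM in this assay

Compound 2 holds the higher of the two numbers, but its nearest neighbour, compound 1, sits so close that the two values lie within the scatter of this assay; the two compounds differ in several places at once, so nothing beyond their two values can be said about them together. Compound 3 `O=c1[nH]c(=O)n(CCC(CO)CO)cc1C#CC1CC1` has not yet been measured. It is reached from compound 2 by the change (cyclopropyl in place of 3,5-difluorophenyl on a triple-bonded carbon), with the replaced group leaving and the new one entering on the triple-bonded carbon described. Among the compounds with values here, no step between measured compounds matches this change, so there is no number to lean on, and the expectation rests on compound 2 alone. Compound 3 is expected to stay near the weak potency of its parent, with a step of a 1.3-fold higher number from compound 2 to compound 3 (0.10 log units; within the scatter) that most likely falls within the scatter or points to a slightly higher number. For compound 3 the estimate is 80000 nM, within a range from 25000 nM to 250000 nM.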

Compound 3, half-maximal inhibitory concentration: > 100000 nM
Compound 3: no number, only a limit; the forecaster's own chance of this, stated with the estimate: 30%; at least 1.2-fold (0.09 log units) between middle value and limit.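

Within the data shown here, this is the first change at a single place: on a triple-bonded carbon, cyclopropyl in place of 3,5-difluorophenyl gives an at least 1.5-fold higher number from compound 2 to compound 3 (0.19 log units; that floor lies within the scatter) in this assay. Compound 3 gives > 100000 nM, which is a limit of the assay and not a number. The change therefore brings no visible gain in potency at this position, although the floor of the step stays within the scatter, so neither a real loss nor its size can be read from it, and the limit marks where the reading stops: the limit of > 100000 nM in this assay, at which 1 of the 3 values shown sits.

The compounds shown leave open whether any group on this triple-bonded carbon can bring the number clearly down from the weak level of compound 2, for instance an amine or a carboxylic acid carried on a short chain. They also leave open how a plain phenyl without the two fluorine atoms would stand against compound 2, which would separate the part played by the ring from that of its fluorine atoms.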